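Difluorophenyl swap on the amide nitrogen: working notes

This account rests on a few compounds, and the source may have more. Where it says the series, first, only, none or still open, it means among the compounds named here.

Values in an in vitro ADME assay on microsomes from liver (Mus musculus) for pharmacokinetics, read by LC-MS, with a stated time of 10 min, tested at 1 uM; a lower number here means slower removal, a higher number faster removal of the compound
- compound 1 `CN1C[C@H](C(=O)Nc2ccc(C#N)cc2)[C@@H](c2ccc(/C=C/C(=O)Nc3ccccc3N)cc2)C1` gives 35 mL/min/kg
- compound 2 `COc1cccc(NC(=O)[C@H]2CN(C)C[C@@H]2c2ccc(/C=C/C(=O)Nc3ccccc3N)cc2)c1` gives 65 mL/min/kg
- compound 3 `CN1C[C@H](C(=O)Nc2ccc(F)c(F)c2)[C@@H](c2ccc(/C=C/C(=O)Nc3ccccc3N)cc2)C1` gives 46 mL/min/kg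

Compound 3 stands within the scatter of both other compounds, with a 1.3-fold higher number from compound 1 to compound 3 (0.12 log units; within the scatter) and a 1.4-fold lower number from compound 2 to compound 3 (0.15 log units; within the scatter). Compound 4 `CN1C[C@H](C(=O)Nc2ccc(F)cc2F)[C@@H](c2ccc(/C=C/C(=O)Nc3ccccc3N)cc2)C1` carries 2,4-difluorophenyl in place of 3,4-difluorophenyl on an amide-type nitrogen. The measured swaps at this nitrogen are those two steps and a 1.9-fold higher number from compound 1 to compound 2 (0.27 log units; within the scatter), all small. Within the data shown here, no measured compound carries 2,4-difluorophenyl, and no step beyond the scatter is expected in this assay. The expected step is no change at the digits printed from compound 3 to compound 4 (within the scatter), with no direction favoured. The estimate for compound 4 is 46 mL/min/kg, with an expected range of 26 mL/min/kg to 78 mL/min/kg.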

Compound 4, clearance: 27 mL/min/kg
Estimate against measurement, compound 4: 1.7-fold (0.23 log units) above; low and high end bracket the measured number.
By their numbers in this assay, from the lowest: compounds 4, 1, 3 and 2 (each within the scatter of the next, the first and the last beyond it).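

In this assay the change to 2,4-difluorophenyl on the amide-type nitrogen gives a 1.7-fold lower number from compound 3 to compound 4 (0.23 log units; within the scatter) and so, with the same atoms joined differently, stays within the scatter. Among the steps at this nitrogen, only a 2.4-fold lower number from compound 2 to compound 4 (0.38 log units; beyond the scatter) lies beyond the scatter and is modest, while a 1.3-fold lower number from compound 1 to compound 4 (0.11 log units; within the scatter) does not, so the swaps here now separate two compounds of the series.

Going by these compounds, whether a cyclohexyl group or a pyridyl ring on this nitrogen would fall inside the same range stays open. Nothing available gives a reason for these steps.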